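Chloro for Ethyl on the Aryl Group of Compound 3

The source may report more compounds than this note shows. Statements on the series, on what has been measured and on what is new or still open speak of the compounds shown alone.

Measured compounds:
Compound 1, `N#CC1=C(N)Oc2c(c3nc4ccccc4nc3c3ccccc23)C12C(=O)N(Cc1cnnn1-c1cccc(Br)c1)c1ccccc12`, in an ADME assay on L02 cells (Homo sapiens) for antiproliferative activity, read by MTT assay, with a stated time of 48 h (a higher number here means a weaker inhibitor, a lower number a stronger inhibitor), gives > 50000 nM, which is a limit of the assay.
Compound 2, `Cc1cccc(-n2nncc2CN2C(=O)C3(C(C#N)=C(N)Oc4c(N)cc5nc6ccccc6nc5c43)c3ccccc32)c1`, in this assay gives > 50000 nM, again a limit.
Compound 3, `CCc1ccccc1-n1nncc1CN1C(=O)C2(C(C#N)=C(N)Oc3c(N)cc4nc5ccccc5nc4c32)c2ccccc21`, in this assay gives 22900 nM.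

Among the measured compounds shown here, compound 3 is the one compound of the three with a number rather than a limit in this assay; the other two sit at the limit of > 50000 nM in this assay, at which 2 of the 3 values shown sit. For the measured compounds named here, the one measured step, an at least 2.1-fold lower number from compound 2 to compound 3 (0.33 log units; beyond the scatter), is the only comparison available, and it concerns a change of the aryl group on the triazole nitrogen.

Compound 4, `N#CC1=C(N)Oc2c(N)cc3nc4ccccc4nc3c2C12C(=O)N(Cc1cnnn1-c1ccccc1Cl)c1ccccc12`, differs from compound 3 in one place: chloro in place of ethyl on an aromatic carbon. Going by the values given here, no measured step exchanges ethyl for chloro, so nothing here tells how a halogen at that position behaves. Among the compounds with values here, the only guide is that two of the three aryl variants stay at the limit while compound 3 alone gives a number, and the step from compound 2 to compound 3 was at least modest in size. On that basis the expected outcome for compound 4 is a value near compound 3 or back toward the limit, a 1.5-fold higher number from compound 3 to compound 4 (0.18 log units; within the scatter), with a fair chance that only a limit is reported. Compound 4 is therefore estimated at 35000 nM, in the range 15000 nM to 80000 nM.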

Compound 4, half-maximal inhibitory concentration: > 50000 nM
Compound 4 ended at the assay's limit; the forecaster's own chance of this, stated with the estimate: 50%; at least 1.4-fold (0.15 log units) between middle value and limit.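

In this assay, chloro in place of ethyl on an aromatic carbon gives an at least 2.1-fold higher number from compound 3 to compound 4 (0.33 log units; beyond the scatter), so the number at this place, ortho to a large group, depends on which group sits there. The earlier readable step exchanged 3-methylphenyl for 2-ethylphenyl and so changed both the group and where it stood, whereas this change leaves the place fixed and alters only the group. It shows that a group at this place is not enough on its own to keep the number seen for compound 3, which remains the only compound of the four with a number rather than a limit: the limit of > 50000 nM in this assay, at which 3 of the 4 values shown sit.

Going by these compounds, the step from compound 2 to compound 4 cannot be read, and how far compound 4 lies past the limit stays unknown. Whether ethyl is unusual at this place also stays open, as the compounds shown do not tell how a longer chain such as propyl, a methoxy group or an amine there would read in this assay.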